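This account rests on a few compounds, and the source may have more. Where it says the series, first, only, none or still open, it means among the compounds named here.

Compound 1 `COc1cc(-c2cc3nccc(-c4cc(OC)c(OC)c(OC)c4)n3n2)cc(OC)c1OC`: in a functional assay on HCT-116 cells (Homo sapiens) for inhibition, read by CCK-8 assay, with a stated time of 48 h (a lower number here means a stronger inhibitor, a higher number a weaker inhibitor), compound 1 gives only a limit, > 10000 nM.
Compound 2 `COc1cc(-c2ccnc3cc(-c4cn(CO)c5ccccc45)nn23)cc(OC)c1OC`: in this assay compound 2 gives 128 nM.
Compound 3 `COc1cc(-c2ccnc3cc(-c4c[nH]c5ccccc45)nn23)cc(OC)c1OC`: in this assay compound 3 gives 35 nM.

For the measured compounds named here, compound 3 stands at the lowest of the two numbers; the nearest is compound 2, and the single measured step, a 3.7-fold lower number from compound 2 to compound 3 (0.56 log units; beyond the scatter), comes from hydrogen in place of hydroxymethyl on an aromatic nitrogen. Compound 1, which carries a second trimethoxyphenyl where compounds 2 and 3 carry the indole, reaches no number at all but only (the limit of > 10000 nM in this assay, at which 1 of the 3 values shown sits).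

Compound 4 `COc1cc(-c2ccnc3cc(-c4ccc(C)c(C)c4)nn23)cc(OC)c1OC` is the next step from compound 3: 3,4-dimethylphenyl in place of 1H-indol-3-yl on an aromatic carbon. The measured step bears on this change only loosely, since it altered a group on the ring nitrogen and kept the indole in place, whereas here the whole indole is exchanged. What compound 1 and compound 3 show is that another aryl group at this carbon can lose all measurable inhibition. A step toward a weaker inhibitor, of modest to large size, is therefore expected in this assay.

Compound 4 is estimated to give 1500 nM, with a range from 200 nM to 10000 nM. That estimate means an expected step of a 43-fold higher number from compound 3 to compound 4 (1.63 log units; beyond the scatter).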

Compound 4, half-maximal inhibitory concentration: 261 nM
Compound 4: middle estimate off by 5.7-fold (0.76 log units), on the high side; the measured number falls inside the stated range.
By their numbers in this assay, from the lowest: compound 3; then compound 2; then compound 4. At a limit, above all of these: compound 1.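

Replacing the 1H-indol-3-yl on this aromatic carbon with 3,4-dimethylphenyl, a ring of carbon only with no hydrogen-bond donor, carries a modest cost in this assay (a 7.5-fold higher number from compound 3 to compound 4 (0.87 log units; beyond the scatter)). The indole's ring nitrogen and its hydrogen are therefore not needed for a measurable number at this place, and an aryl group at this carbon does not by itself lose all inhibition. The exact aryl group still matters, as compound 1, with trimethoxyphenyl at this carbon, gives only a limit: the limit of > 10000 nM in this assay, at which 1 of the 4 values shown sits.

As far as these compounds go, whether a plain phenyl or a single methyl on the ring would land nearer compound 3 or compound 4 remains open. Also open, from the compounds shown here alone, is how a pyridine ring, an amine or a carboxylic acid at this place would change the number.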